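Removing the Fluorophenyl Ring from a Penicillanate Enone

The compounds below may be only part of what the source reports. "The series", "measured", "known", "first", "only" and "open" are said of these compounds alone.

Of the compounds shown here, two have been measured. Compound 1 `CC1(C)S[C@@H]2/C(=C\C(=O)c3ccc(F)cc3)C(=O)N2[C@H]1C(=O)OC(c1ccccc1)c1ccccc1` gives 17800 nM in a functional assay on A-375 cells (Homo sapiens) for cytotoxicity, read by MTT assay, with a stated time of 48 h; on this read-out lower numbers stand for stronger inhibition and higher numbers for weaker inhibition; this is the highest of the two numbers seen. Compound 2 `CC1(C)[C@H](C(=O)OC(c2ccccc2)c2ccccc2)N2C(=O)/C(=C/C(=O)c3ccccc3)[C@H]2[S+]1[O-]` gives 4500 nM, a lower number than compound 1, and the gap between the two lies beyond the usual scatter. For the measured compounds named here, compound 2 differs from compound 1 in more than one place, so no single step between them can be read off.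

Compound 3 `CC(=O)/C=C1/C(=O)N2[C@@H]1SC(C)(C)[C@@H]2C(=O)OC(c1ccccc1)c1ccccc1` is the next compound, not yet measured. It differs from compound 1 in one place: methyl in place of 4-fluorophenyl on a carbonyl carbon. Put another way, the (4-fluorophenyl)carbonyl of compound 1 becomes an acetyl in compound 3. Going by the values given here, there is no measured pair here that shows what such a change does in this assay, so the direction is open. The expected step of a 1.4-fold higher number from compound 1 to compound 3 (0.15 log units; within the scatter) is therefore small, likely towards a somewhat higher number, and may fall within the scatter. Compound 3 is estimated at 25000 nM, with a range from 8000 nM to 80000 nM.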

Compound 3, half-maximal inhibitory concentration: 63000 nM
Compound 3: middle estimate off by 2.5-fold (0.40 log units), on the low side; measured number inside the range.
By their numbers in this assay, from the lowest: compound 2; then compound 1; then compound 3.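

On the carbonyl carbon whose other neighbour is the double-bonded chain carbon, the group carried there matters in this assay, as replacing 4-fluorophenyl with methyl gives a 3.5-fold higher number from compound 1 to compound 3 (0.55 log units; beyond the scatter). This is the first comparison among these compounds that changes one place only, and it shows that, for this pair, the version with the aromatic ring has the lower number. No measurement at hand accounts for the shift, so the step stands as an observation only.

On these data alone, it remains open whether the fluorine or the ring itself carries the step, since compound 2, with a plain phenyl here, differs from compound 1 in more than one place. Also open, as far as these compounds go, is what a longer chain such as propyl, or an amine, would do on this carbonyl carbon.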